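Changing the Amide Group on Compound 3

The source may report more compounds than this note shows. Statements on the series, on what has been measured and on what is new or still open speak of the compounds shown alone.

The compounds here share one core and differ in the group on an amide-type nitrogen, followed in a physicochemical assay for solubility, read by HPLC, in simulated intestinal fluid, with a stated time of 16 h, at pH 6.5, tested at 2.5 mg/mL; a higher number here means a more soluble compound, a lower number a less soluble compound. Among the compounds with values here, compound 3 `CNC(=O)c1cc(C(=O)NC2CC2)cc2c1OC[C@@]2(C)c1ccccc1` gives 585 ug/mL, the higher of the two true numbers so far. Compound 2 `CNC(=O)c1cc(C(=O)N[C@H]2[C@@H]3COC[C@@H]32)cc2c1OC[C@@]2(C)c1ccccc1` gives 80 ug/mL. Compound 1 `CNC(=O)c1cc(C(=O)N[C@H]2CC[C@H](O)CC2)cc2c1OC[C@@]2(C)c1ccccc1` reads >= 1000 ug/mL, which is a limit of the assay and not a number.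

Compound 4 `CNC(=O)c1cc(C(=O)N[C@H]2[C@@H]3C[C@@H](O)C[C@@H]32)cc2c1OC[C@@]2(C)c1ccccc1` differs from compound 3 by one change: a group of 7 heavy atoms (6 carbon, 1 oxygen; one three-membered non-aromatic ring of carbon only, one five-membered non-aromatic ring of carbon only) in place of a group of 3 heavy atoms (3 carbon; one three-membered non-aromatic ring of carbon only), on an amide-type nitrogen.

Within the data shown here, three measured steps bear on this change, and they pull in different directions. The new group holds a three-membered non-aromatic ring of carbon only, as the group in the large step of an at least 12-fold lower number from compound 1 to compound 2 (1.09 log units; beyond the scatter) does. That group is also involved in the modest step of a 7.3-fold higher number from compound 2 to compound 3 (0.86 log units; beyond the scatter). However, the new group bears a hydroxy as 4-hydroxycyclohexyl does, and an at least 1.7-fold lower number from compound 1 to compound 3 (0.23 log units; that floor lies within the scatter) has a floor within the scatter.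

No change beyond the scatter is therefore expected, and the estimated step is a 1.3-fold lower number from compound 3 to compound 4 (0.11 log units; within the scatter). For compound 4 the expected value is 450 ug/mL, with an estimated range of 130 ug/mL to 1000 ug/mL.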

Compound 4, solubility: > 1000 ug/mL
Compound 4 was reported as a limit; the forecaster's own chance of this, stated with the estimate: 25%; middle value at least 2.2-fold (0.34 log units) from the limit.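

Compound 4 reads as a limit of the assay and not a number: the limit of > 1000 ug/mL in this assay, at which 1 of the 4 values shown sits.

In this assay, this group gives an at least 1.7-fold higher number from compound 3 to compound 4 (0.23 log units; that floor lies within the scatter), a floor that cannot separate it from cyclopropyl, and an at least 12-fold higher number from compound 2 to compound 4 (1.09 log units; beyond the scatter), which is beyond the scatter. Compound 2 and compound 4 both hold a three-membered ring of carbon, so among these compounds that ring does not always go with a low number, while the step between compound 1 and compound 4 cannot be read, as both values are limits.

On these data alone, how far compound 4 lies past its limit stays open, as does the order of compound 1 and compound 4. An amine or a methoxy in place of the hydroxy on the same group would show whether the hydroxy matters for this reading.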